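Furan for thiophene on the amide carbonyl of compound 1

The source may hold more compounds than are shown below. What is called first, only, known or untested is meant among the compounds shown, and "the series" means these compounds.

Measured compounds:
compound 1, `COc1ccc(S(=O)(=O)N2CCc3cccc(NC(=O)c4cccs4)c32)cc1`, 49 nM
compound 2, `COc1ccc(S(=O)(=O)N2CCc3cccc(NC(=O)c4ccncc4)c32)cc1`, 9.4 nM
compound 3, `COc1ccc(S(=O)(=O)N2CCc3cccc(NCc4ccccc4)c32)cc1`, > 10000 nM

In a functional assay on NCI-H460 cells (Homo sapiens) for cytotoxicity (a lower number here means a stronger inhibitor, a higher number a weaker inhibitor), compound 1 gives 49 nM, the higher of the two numbers measured in this series; the nearest is compound 2, as shown by a 5.2-fold lower number from compound 1 to compound 2 (0.72 log units; beyond the scatter). For compound 3 this assay reports only a limit, > 10000 nM, not a number.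

Compound 4, `COc1ccc(S(=O)(=O)N2CCc3cccc(NC(=O)c4ccco4)c32)cc1`, has not yet been measured in this assay. It differs from compound 1 at one place: furan-2-yl in place of thiophen-2-yl on a carbonyl carbon. The relevant measured step is the other swap of the aryl group on the carbonyl carbon, a 5.2-fold lower number from compound 1 to compound 2 (0.72 log units; beyond the scatter), which was modest. The steps of an at least 200-fold higher number from compound 1 to compound 3 (2.30 log units; beyond the scatter) and an at least 1000-fold higher number from compound 2 to compound 3 (3.02 log units; beyond the scatter) were large, but both replace the whole carbonyl-bearing group with benzyl on the ring nitrogen and so do not bear directly on a thiophen-2-yl to furan-2-yl exchange that keeps the amide. The expectation for compound 4 is therefore a step of about none beyond the scatter, or at most a modest one, with a 1.0-fold higher number from compound 1 to compound 4 (0.01 log units; within the scatter). Compound 4 is estimated at 50 nM, in the range 15 nM to 160 nM.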

Compound 4, half-maximal inhibitory concentration: 9.8 nM
Beside the measured number, compound 4's estimate is 5.1-fold (0.71 log units) above it, outside the stated range (below it).
By their numbers in this assay, from the lowest: compounds 2 and 4 (each within the scatter of the next); then compound 1. At a limit, above all of these: compound 3.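

In this assay, going by these compounds alone, exchanging one five-membered aromatic ring for another on the carbonyl carbon is not a silent change (a 5.0-fold lower number from compound 1 to compound 4 (0.70 log units; beyond the scatter)), so the hetero atom of this ring matters here, which the earlier compounds could not show. Compound 2 and compound 4 lie within the scatter of each other (a 1.0-fold higher number from compound 2 to compound 4 (0.02 log units; within the scatter)), leaving thiophen-2-yl as the one group that goes against the other two among these amides. The amide with furan-2-yl is also separated from the benzyl amine by a large step (an at least 1000-fold lower number from compound 3 to compound 4 (3.00 log units; beyond the scatter)), and that step rests on a value for compound 3 that is a limit: the limit of > 10000 nM in this assay, at which 1 of the 4 values shown sits.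

Open, going by these compounds, is whether phenyl, thiazol-2-yl or furan-3-yl on the carbonyl carbon would match furan-2-yl or thiophen-2-yl. Also open, on these data alone, is whether a saturated ring such as morpholine or a short alkyl chain would be tolerated there.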